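The source may report more compounds than this note shows. Statements on the series, on what has been measured and on what is new or still open speak of the compounds shown alone.

Three members of a shared urea series have been measured in a functional assay on A498 cells (Homo sapiens) for inhibition, read by sulforhodamine B assay, with a stated time of 48 h; a lower number here means a stronger inhibitor of growth, a higher number a weaker inhibitor of growth. Compound 1, `O=C(Nc1cccc(-n2cc(-c3ccncc3)c(-c3ccc(Cl)c(O)c3)n2)c1)Nc1cccc(C(F)(F)F)c1`, gives 2240 nM in this assay. Compound 2, `COc1cc(-c2nn(-c3cccc(NC(=O)Nc4cc(C(F)(F)F)cc(C(F)(F)F)c4)c3)cc2-c2ccncc2)ccc1Cl`, gives 612 nM. Compound 3, `COc1cc(-c2nn(-c3cccc(NC(=O)Nc4ccc(Cl)c(Cl)c4)c3)cc2-c2ccncc2)ccc1Cl`, gives 1140 nM, which places it second highest of the three numbers: its nearest neighbour is compound 2, at a lower number that stays within the scatter, and its furthest is compound 1, at a higher number that also stays within the scatter. Among the measured compounds shown here, on these three values alone no compound can be called stronger or weaker than another.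

Compound 4, `COc1cc(-c2nn(-c3cccc(NC(=O)Nc4cccc(C(F)(F)F)c4)c3)cc2-c2ccncc2)ccc1Cl`, is compound 3 with one change: 3-(trifluoromethyl)phenyl in place of 3,4-dichlorophenyl on an amide-type nitrogen. For the measured compounds named here, no step between measured compounds repeats this exact exchange, so its size has to be judged from the surrounding numbers. Compound 2, which carries two trifluoromethyl groups on the same ring, and compound 3, with its dichloro pattern, sit within the scatter of each other, and compound 1, which shares the incoming group with compound 4 but differs elsewhere, sits within the scatter of compound 3 as well. The step from compound 3 to compound 4 is therefore expected to be small, a 1.1-fold higher number from compound 3 to compound 4 (0.02 log units; within the scatter), with no clear direction beyond the scatter. Compound 4 is estimated at 1200 nM in this assay, within a range from 500 nM to 3000 nM.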

Compound 4, concentration for 50% growth inhibition: 958 nM
Beside the measured number, compound 4's estimate is 1.3-fold (0.10 log units) above it; the measured number falls inside the stated range.
By their numbers in this assay, from the lowest: compounds 2, 4, 3 and 1 (each within the scatter of the next, the first and the last beyond it).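

In this assay, the exchange at the amide-type nitrogen gives a 1.2-fold lower number from compound 3 to compound 4 (0.08 log units; within the scatter), and removing one of the two trifluoromethyl groups on that same ring gives a 1.6-fold higher number from compound 2 to compound 4 (0.19 log units; within the scatter), so neither of these one-place changes to the urea's aromatic ring can be read as a change in growth inhibition. Compound 4 also provides a one-place comparison for the oxygen on the other aromatic ring: methyl in place of hydrogen there gives a 2.3-fold lower number from compound 1 to compound 4 (0.37 log units; beyond the scatter), a modest step and the only one of the three that lies beyond the scatter, with compound 4 the stronger inhibitor of growth of that pair. Nothing available explains the size of any of these steps.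

The compounds shown leave open whether the step from hydrogen to methyl on that oxygen carries over when the urea bears 3,4-dichlorophenyl or the ring with two trifluoromethyl groups, since only one such pair is shown. They also leave open what a longer chain such as ethyl on that oxygen, or an amine or a carboxylic acid on the urea's aromatic ring, would do to the number.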